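This account rests on a few compounds, and the source may have more. Where it says the series, first, only, none or still open, it means among the compounds named here.

Measured so far in an assay on cells for agonist activity at ecdysone receptor (Bombyx mori), read by a luciferase reporter, with a stated time of 24 h; on this read-out higher numbers stand for an effect only at larger amounts of compound and lower numbers for an effect already at smaller amounts: compound 1 `CC(C)(C)N(NC(=O)c1cccc(Cl)c1)C(=O)c1ccccc1Cl` gives 155 nM; compound 2 `Cc1cccc(C(=O)NN(C(=O)c2ccccc2Cl)C(C)(C)C)c1` gives 603 nM; compound 3 `CC(C)(C)N(NC(=O)c1ccc(C#N)cc1)C(=O)c1ccccc1Cl` gives 603 nM.

On these numbers compound 3 shares the highest value of the three, the step of no change at the digits printed from compound 2 to compound 3 (within the scatter) showing no difference at all, while the step of a 3.9-fold higher number from compound 1 to compound 3 (0.59 log units; beyond the scatter) is the largest gap it shows. Compound 4 `Cc1cccc(C(=O)NN(C(=O)c2ccccc2Cl)C(C)(C)C)c1C` differs from compound 3 in one place: 2,3-dimethylphenyl in place of 4-cyanophenyl on a carbonyl carbon. Among the measured compounds shown here, the step of no change at the digits printed from compound 2 to compound 3 (within the scatter) bears directly on this change, since it exchanged the same two ring types apart from the second methyl; no measured step adds that second methyl. The expected step of a 1.5-fold lower number from compound 3 to compound 4 (0.18 log units; within the scatter) in this assay is therefore small, and compound 4 is estimated at 400 nM, between 100 nM and 1500 nM.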

Compound 4, half-maximal effective concentration: 20 nM
For compound 4 the middle estimate is 20-fold (1.30 log units) above the measured one, and the stated range ends above it.
By their numbers in this assay, from the lowest: compound 4; then compound 1; then compounds 2 and 3 (each within the scatter of the next).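

In this assay, among the compounds shown here, the ring on the carbonyl carbon proves far more sensitive than the earlier steps suggested, since one added methyl gives a 30-fold lower number from compound 2 to compound 4 (1.48 log units; beyond the scatter) and so turns a 3-methylphenyl ring into a much better one. The 2,3-dimethylphenyl ring also gives a 30-fold lower number from compound 3 to compound 4 (1.48 log units; beyond the scatter) against 4-cyanophenyl and a 7.8-fold lower number from compound 1 to compound 4 (0.89 log units; beyond the scatter) against 3-chlorophenyl, making compound 4 the lowest number of the four. No measurement here explains this drop. As far as these compounds go, whether an ethyl or a methoxy group in place of the added methyl would keep so low a number stays open.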